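A chlorophenyl in place of a methoxyphenyl on the side chain

A few compounds are considered here, and "the series" means these few. Any claim that something is new, unique, unknown or untested is made for them only; others in the source may bear on it.

Compound 1 `CCCCc1cnc(Cc2ccc(-c3ccccc3C(=O)O)cc2)[nH]1`, compound 2 `CCCCc1cnc(C(C)Cc2ccc(-c3ccccc3C(=O)O)cc2)[nH]1` and compound 3 `COc1cccc(Cc2cnc(CCc3ccc(-c4ccccc4C(=O)O)cc3)[nH]2)c1` share a core and were tested in an in vitro functional assay on cells for agonist activity at Bombesin receptor subtype-3 (Mus musculus), read by luminescence and calcium flux; a higher number here means that more compound is needed for the effect, a lower number that less compound is needed. In this assay compound 1 reaches only a limit, > 10000 nM. Compound 2 gives 184 nM. Compound 3 gives 79 nM, the lowest of the two numbers, and compound 2, its nearest neighbour, sits a step higher that is beyond the usual scatter.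

Compound 4 `O=C(O)c1ccccc1-c1ccc(CCc2ncc(Cc3ccc(Cl)cc3)[nH]2)cc1` has not been measured. It differs from compound 3 by 4-chlorophenyl in place of 3-methoxyphenyl on a saturated chain carbon bound to an aromatic carbon. No measured pair among the compounds shown covers a change of this kind, so the expected step is a 1.3-fold lower number from compound 3 to compound 4 (0.12 log units; within the scatter), small and without a clear direction beyond the scatter. Compound 4 is estimated at 60 nM, within a range from 15 nM to 250 nM.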

Compound 4, half-maximal effective concentration: 102 nM
The estimate for compound 4 lay 1.7-fold (0.23 log units) below the measured number; the range from low to high includes it.
By their numbers in this assay, from the lowest: compounds 3, 4 and 2 (each within the scatter of the next, the first and the last beyond it). At a limit, above all of these: compound 1.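

In this assay, 4-chlorophenyl in place of 3-methoxyphenyl on a saturated chain carbon bound to an aromatic carbon gives a 1.3-fold higher number from compound 3 to compound 4 (0.11 log units; within the scatter). This is the first change of this group among the compounds shown, and the two aromatic groups leave the number within the scatter. Nothing shown accounts for this result.

Still open, on these data alone, is how the choice of chlorine or methoxy and its ring location would each count alone: a 3-chlorophenyl group would separate them. As far as these compounds go, a 4-aminophenyl group at this place also remains open.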